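The source may report more compounds than this note shows. Statements on the series, on what has been measured and on what is new or still open speak of the compounds shown alone.

Measured so far:
- compound 1 `COc1ccc(/C=C/S(=O)(=O)Nc2c(F)c(F)c(F)c(F)c2F)cc1[N+](=O)[O-]`: 75000 nM
- compound 2 `O=S(=O)(/C=C/c1ccccc1)Nc1ccc(Cl)cc1`: 20000 nM
- compound 3 `COC(=O)C(C)Nc1cc(NS(=O)(=O)/C=C/c2c(OC)cc(OC)cc2OC)ccc1OC`: 300 nM

All three values come from a functional assay on K562 cells (Homo sapiens) for cytotoxicity, read by trypan blue exclusion, with a stated time of 96 h; on this read-out lower numbers stand for stronger inhibition and higher numbers for weaker inhibition. Of these three numbers, compound 3 gives the lowest, clearly beyond the usual scatter of repeated measurements. Compound 2 lies nearest to it, and compound 1 lies furthest away.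

Compound 4 `COc1cc(OC)c(/C=C/S(=O)(=O)Nc2ccc(OC)c(NC(C)C(=O)O)c2)c(OC)c1` has not yet been measured. It differs from compound 3 in one place: hydrogen in place of methyl on an oxygen next to a carbonyl group. Hydrogen stands in place of methyl on an oxygen next to a carbonyl group, turning 1-(methoxycarbonyl)ethyl into 1-carboxyethyl.

Going by the values given here, no two measured compounds differ in only one place, so no measured step shows what this change does in this assay. The expectation therefore starts from compound 3 at 300 nM and carries wide uncertainty. The expected 3.0-fold higher number from compound 3 to compound 4 (0.48 log units; beyond the scatter) points to a somewhat higher number, meaning weaker inhibition, though a result with no change beyond the scatter remains possible. For compound 4 the estimated value is 900 nM, with an expected range from 150 nM to 6000 nM.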

Compound 4, half-maximal inhibitory concentration: 8 nM
Compound 4: the middle estimate sits 110-fold (2.05 log units) above what was measured; measured number below the stated range.
By their numbers in this assay, from the lowest: compound 4; then compound 3; then compound 2; then compound 1.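

Going by these compounds alone, the earlier compounds included no pair differing in only one place, so this is the first direct reading of a single change in this assay. Hydrogen in place of methyl on an oxygen next to a carbonyl group turns 1-(methoxycarbonyl)ethyl into 1-carboxyethyl and gives a 38-fold lower number from compound 3 to compound 4 (1.57 log units; beyond the scatter), a large step beyond the scatter. The loss of a single carbon at this one place is thus enough to shift the number strongly, and no measurement at hand accounts for the shift.

As far as these compounds go, whether a carboxamide, a primary alcohol or a longer chain ending in a carboxylic acid would give a similarly low number at this place stays open. So does whether the same exchange of methyl for hydrogen would give a step of this size on a different core.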